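The source may report more compounds than this note shows. Statements on the series, on what has been measured and on what is new or still open speak of the compounds shown alone.

In a functional assay on HepG2 cells (Homo sapiens) for cytotoxicity (a lower number here means a stronger inhibitor, a higher number a weaker inhibitor), compound 1 `N#C/N=C1\N(CCCCCOc2ccc(Cl)cc2)C(=O)CN1c1ccncc1` gives 4200 nM. Compound 2 `N#C/N=C1\N(CCCCCCOc2ccc(Cl)cc2)C(=O)CN1c1ccncc1` differs from it by (4-chlorophenoxy)methyl in place of 4-chlorophenoxy on a saturated chain carbon, five bonds along the chain from an amide-type nitrogen in a ring, and in this assay compound 2 gives 392 nM, a step of an 11-fold lower number from compound 1 to compound 2 (1.03 log units; beyond the scatter). Compound 3 `N#C/N=C1\N(CCCCCOc2ccc(Cl)cc2)C(=O)C(c2ccccc2)N1c1ccncc1` has a different core, differing from compound 1 by phenyl in place of hydrogen on a saturated ring carbon; in this assay compound 3 gives 415 nM, a step of a 10-fold lower number from compound 1 to compound 3 (1.01 log units; beyond the scatter). Compound 4 `N#C/N=C1\N(CCCCCCOc2ccc(Cl)cc2)C(=O)C(c2ccccc2)N1c1ccncc1` is not yet measured and differs from compound 3 by (4-chlorophenoxy)methyl in place of 4-chlorophenoxy on a saturated chain carbon, five bonds along the chain from an amide-type nitrogen in a ring, the same change that turned compound 1 into compound 2, at the same place. Because the step of an 11-fold lower number from compound 1 to compound 2 (1.03 log units; beyond the scatter) was large, a step of broadly similar size is expected here, estimated as an 8.3-fold lower number from compound 3 to compound 4 (0.92 log units; beyond the scatter). Compound 4 is therefore expected to give about 50 nM, most likely between 15 nM and 200 nM.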

Compound 4, half-maximal inhibitory concentration: 44 nM
Compound 4: middle estimate off by 1.1-fold (0.06 log units), on the high side; low and high end bracket the measured number.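

In this assay, (4-chlorophenoxy)methyl in place of 4-chlorophenoxy gives a 9.4-fold lower number from compound 3 to compound 4 (0.97 log units; beyond the scatter), and the change carries over between the two cores with little difference in size: the same change on two cores in this assay, an 11-fold lower number (1.03 log units; beyond the scatter) from compound 1 to compound 2 and a 9.4-fold lower number (0.97 log units; beyond the scatter) from compound 3 to compound 4, 1.1-fold (0.06 log units) apart, within the scatter of two such steps. Phenyl in place of hydrogen on the saturated ring carbon gives an 8.9-fold lower number from compound 2 to compound 4 (0.95 log units; beyond the scatter), and it too holds on both chains: the same change on two cores in this assay, a 10-fold lower number (1.01 log units; beyond the scatter) from compound 1 to compound 3 and an 8.9-fold lower number (0.95 log units; beyond the scatter) from compound 2 to compound 4, 1.1-fold (0.06 log units) apart, within the scatter of two such steps. The two changes therefore behave as if they add up across these four compounds, but this rests on a single square of compounds in one assay and does not show why the number falls or whether other cores would behave alike.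

From the compounds shown here alone, a still longer chain, such as one ending in 2-(4-chlorophenoxy)ethyl, remains open. So does a methyl or an amine in place of phenyl on that ring carbon.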